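Cyano gives way to methoxy on the shared core

This account rests on a few compounds, and the source may have more. Where it says the series, first, only, none or still open, it means among the compounds named here.

In a functional assay on DLD-1 cells (Homo sapiens) for cytotoxicity, with a stated time of 48 h (on this read-out lower numbers stand for stronger inhibition and higher numbers for weaker inhibition), compound 2 (`C[S+]([O-])/C=C/c1cc(=O)c2cc(C#N)ccc2o1`) shows > 10000 nM as a limit and not a number. Compound 1 (`CCOc1ccc2oc(/C=C/[S+](C)[O-])cc(=O)c2c1`) gives 4900 nM in the same test. Compound 3 (`COc1ccc2oc(/C=C/[S+](C)[O-])cc(=O)c2c1`) has methoxy in place of cyano on an aromatic carbon. Among the compounds with values here, the one measured step that bears on this, cyano in place of ethoxy on an aromatic carbon, was an at least 2.0-fold higher number from compound 1 to compound 2 (0.30 log units; that floor lies within the scatter) and gives only a floor. Within the data shown here, compound 1 at 4900 nM is the sole numerical guide, so a move toward lower numbers is expected. The expected step is an at least 1.8-fold lower number from compound 2 to compound 3 (0.25 log units; that floor lies within the scatter) in this assay overall. For compound 3 the estimate is 5500 nM within an expected range from 2500 nM to 10000 nM overall.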

Compound 3, half-maximal inhibitory concentration: 5700 nM
Compound 3: the middle estimate sits 1.0-fold (0.02 log units) below what was measured, within the range that was stated.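

In this assay, methoxy in place of cyano on this aromatic carbon gives an at least 1.7-fold lower number from compound 2 to compound 3 (0.24 log units; that floor lies within the scatter), which is only a floor. Compound 2 carries a limit and not a number: the limit of > 10000 nM in this assay, at which 1 of the 3 values shown sits.

Moving from ethoxy to methoxy gives a 1.2-fold higher number from compound 1 to compound 3 (0.07 log units; within the scatter), so the two ether groups cannot be told apart at this position. The compounds shown leave open whether the true gap between cyano and methoxy lies beyond the scatter. They also leave open how an amine, a carboxylic acid or an ether chain longer than ethoxy would read on this carbon.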